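The compounds below may be only part of what the source reports. "The series", "measured", "known", "first", "only" and "open" are said of these compounds alone.

Measured so far:
- compound 1, `Cc1cc(Nc2cc(Cl)ccc2Cl)nc(N)n1`: > 180000 nM
- compound 2, `COc1ccc(-c2cc(Cl)cc(Nc3cc(C)nc(N)n3)c2)cc1`: > 180000 nM

Both compounds were tested in an assay on cells for inhibition of S-adenosylmethionine decarboxylase proenzyme (Homo sapiens), read by mass spectrometry, at pH 7.2; a lower number here means a stronger inhibitor, a higher number a weaker inhibitor. For compound 1 the result is a limit of the assay and not a number, > 180000 nM. Compound 2 likewise returns a limit rather than a number, > 180000 nM. Compound 2 therefore cannot be placed above or below any companion: the limit of > 180000 nM in this assay, at which 2 of the 2 values shown sit, and nothing here separates one compound from the other.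

The next compound, compound 3 `CC(=O)c1ccc(-c2cc(Cl)cc(Nc3cc(C)nc(N)n3)c2)cc1`, differs from compound 2 in one place: acetyl in place of methoxy on an aromatic carbon. Within the data shown here, no pair of measured compounds differing in a single place is available, so no measured step can be consulted for the size or direction of such a change. With compound 2 giving only a limit, the plain expectation is that compound 3 stays at or near the same limit, and any shift beyond the scatter of this assay would be a surprise in either direction. Compound 3 is accordingly expected to give about 200000 nM, with a plausible range of 90000 nM to 1000000 nM. The expected step is a step that the limit leaves unreadable from compound 2 to compound 3, nothing beyond the scatter.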

Compound 3, half-maximal inhibitory concentration: > 21000 nM
Compound 3: no number, only a limit; the forecaster's own chance of this, stated with the estimate: 80%; the middle value lies beyond the limit too.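

In this assay compound 3 gives a limit and not a number, > 21000 nM. Compound 2 also gives a limit, > 180000 nM. No step can be read between compound 2 and compound 3. The compounds shown leave open what acetyl in place of methoxy does to inhibition, and whether any of these compounds reaches a measurable value in this assay.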